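Shortening the Amino-Acyl Chain: From Compound 2 to Compound 3

The source may hold more compounds than are shown below. What is called first, only, known or untested is meant among the compounds shown, and "the series" means these compounds.

Compound 1, `COc1cc(N)c(Cl)cc1C(=O)NC1CCN(CC2CCN(CC(C)CN)CC2)CC1`, gives 14.3 nM.
Compound 2, `COc1cc(N)c(Cl)cc1C(=O)NC1CCN(CC2CCN(C(=O)CCCCN)CC2)CC1`, gives 3.91 nM.

Both numbers come from an assay on striatum for inhibition of 5-hydroxytryptamine receptor 4 (Cavia porcellus), read by radioligand binding; on this read-out lower numbers stand for stronger inhibition and higher numbers for weaker inhibition. Compound 2 stands at the lowest of the two numbers shown, and its only neighbour is compound 1, separated by the step of a 3.7-fold lower number from compound 1 to compound 2 (0.56 log units; beyond the scatter). Compound 3, `COc1cc(N)c(Cl)cc1C(=O)NC1CCN(CC2CCN(C(=O)CCN)CC2)CC1`, has not yet been measured. It differs from compound 2 by amino in place of 2-aminoethyl on a saturated chain carbon, two bonds along the chain from a carbonyl carbon; read one bond further out, the change is (4-aminobutyl)carbonyl to (2-aminoethyl)carbonyl, a shortening of the chain that carries the terminal amine. For the measured compounds named here, the one measured step bears only loosely on this, since it exchanged both the link to the ring nitrogen and the chain at once, so it gives no clear direction for a pure shortening. The expected step from compound 2 to compound 3 is therefore a 1.5-fold higher number from compound 2 to compound 3 (0.19 log units; within the scatter), likely within the scatter. Compound 3 is estimated at 6 nM, with a range from 2 nM to 20 nM.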

Compound 3, half-maximal inhibitory concentration: 9.5 nM
Estimate against measurement, compound 3: 1.6-fold (0.20 log units) below; the measured number falls inside the stated range.
By their numbers in this assay, from the lowest: compound 2; then compounds 3 and 1 (each within the scatter of the next).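

For the compounds shown here, with the carbonyl link held fixed, this is the first step that changes only the length of the chain carrying the terminal amine. In this assay the change from (4-aminobutyl)carbonyl to (2-aminoethyl)carbonyl gives a 2.4-fold higher number from compound 2 to compound 3 (0.39 log units; beyond the scatter), so chain length alone moves the number, and the longer of these two chains gives the lower value. The carbonyl link does not by itself set a compound apart from compound 1, since a 1.5-fold lower number from compound 1 to compound 3 (0.18 log units; within the scatter).

The data offer no explanation for why these chains differ. Going by these compounds, it also remains open whether (3-aminopropyl)carbonyl would fall between the two chains, whether a chain longer than 4-aminobutyl would lower the number further, and whether the terminal amine could be replaced by a hydroxyl or a carboxylic acid.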